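The source may hold more compounds than are shown below. What is called first, only, known or untested is meant among the compounds shown, and "the series" means these compounds.

Measured in a functional assay on BXPC-3 cells (Homo sapiens) for antiproliferative activity, read by sulforhodamine B assay, with a stated time of 72 h; on this read-out higher numbers stand for weaker inhibition and lower numbers for stronger inhibition:
Compound 1 `O=C(c1cccc(/C=c2\[nH]c(=O)/c(=C/c3ccccn3)[nH]c2=O)c1)N1CCCCC1`: > 500 nM
Compound 2 `CC(C)(C)c1[nH]cnc1/C=c1\[nH]c(=O)/c(=C/c2cccc(C(=O)c3cccnc3)c2)[nH]c1=O`: 4.05 nM

The entry for compound 1 is a limit of the assay and not a number. Within the data shown here, that leaves compound 2, at 4.05 nM, with the only true number so far, which makes it the natural starting point for what comes next.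

Compound 3 `CC(C)(C)c1[nH]cnc1/C=c1\[nH]c(=O)/c(=C/c2cccc(C(=O)c3ccco3)c2)[nH]c1=O` differs from compound 2 in a single place, with furan-2-yl in place of pyridin-3-yl on a carbonyl carbon. Among the measured compounds shown here, no measured pair shows what such a swap does. For the measured compounds named here, the only guide is compound 2 at 4.05 nM, so in this assay no shift beyond the usual scatter is expected, in either direction. The expected change is a 1.0-fold lower number from compound 2 to compound 3 (0.01 log units; within the scatter). The estimate for compound 3 is 4 nM, with an expected range of 1.3 nM to 14 nM.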

Compound 3, half-maximal inhibitory concentration: 9.23 nM
Beside the measured number, compound 3's estimate is 2.3-fold (0.36 log units) below it; measured number inside the range.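

Among these compounds, this is the first measured swap at this place, on a carbonyl carbon. In this assay, putting furan-2-yl in place of pyridin-3-yl gives a 2.3-fold higher number from compound 2 to compound 3 (0.36 log units; beyond the scatter), a modest loss of inhibition, so the place accepts a five-membered aromatic ring with an oxygen, but not with quite the same strength as a six-membered aromatic ring with a nitrogen. The data give only the size of this step, and nothing measured here bears on its cause.

With just these two rings compared, ring size and the kind of hetero atom cannot be told apart. A plain phenyl ring on the same carbonyl carbon would help to separate the two, and an open ethyl chain there would test whether any ring is needed at all.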